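This account rests on a few compounds, and the source may have more. Where it says the series, first, only, none or still open, it means among the compounds named here.

Measured so far:
compound 1 `CCOC(=O)C1=C(C)N/C(=C/c2cc(C)n(-c3ccc(N(C)C)cc3)c2C)C1=O` gives 3.4 in a physicochemical assay for lipophilicity, read by HPLC, at pH 7.4; a higher number here means a more lipophilic compound, a lower number a more polar compound
compound 2 `CCOC(=O)C1=C(C)N/C(=C/c2cc(C)n(-c3ccc(SC(F)(F)F)cc3)c2C)C1=O` gives "not determined" (no result reported) in this assay
compound 3 `CCOC(=O)C1=C(C)N/C(=C/c2cc(C)n(-c3ccc(S(=O)(=O)C(F)(F)F)cc3)c2C)C1=O` gives "not determined" (no result reported) in this assay

Among the measured compounds shown here, compound 1 therefore holds the only number in this assay; compounds 2 and 3 stand beside it without a value, so no step between two measured compounds can be drawn from this set. The change from compound 1 to compound 4 `CCOC(=O)C1=C(C)N/C(=C/c2cc(C)n(-c3cccnc3)c2C)C1=O` is pyridin-3-yl in place of 4-(dimethylamino)phenyl on an aromatic nitrogen. For the measured compounds named here, with no measured step to lean on, the expectation rests on the structural change alone: a step down in this assay beyond the usual scatter is expected, namely a number 1.10 log units lower from compound 1 to compound 4 (beyond the scatter). Compound 4 is accordingly estimated at 2.3, with a range from 1.8 to 2.8.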

Compound 4, distribution coefficient: 2.1
Beside the measured number, compound 4's estimate is 0.20 log units above it; measured number inside the range.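

In this assay, among the compounds shown here, pyridin-3-yl in place of 4-(dimethylamino)phenyl gives a number 1.30 log units lower from compound 1 to compound 4 (beyond the scatter) and so provides the first measured step at this position. It shows that changing only the group on this aromatic nitrogen, with the rest of the core the same, can move the number by a large step. Nothing measured here accounts for the size of that step. The compounds shown leave open how much of the step belongs to losing the dimethylamino group and how much to the ring nitrogen of pyridin-3-yl. An unsubstituted phenyl group on this nitrogen would separate the two.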